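Series notes: aryl swap on the ring nitrogen

The source may hold more compounds than are shown below. What is called first, only, known or untested is meant among the compounds shown, and "the series" means these compounds.

Measured so far:
- Compound 1 `COc1ccc(-n2cc(COc3c(/C=C\C(=O)O)ccc(OC)c3CC=C(C)C)nn2)cc1`: in a functional assay on NCI-H322 cells (Homo sapiens) for cytotoxicity, read by MTT assay, with a stated time of 24 h (on this read-out lower numbers stand for stronger inhibition and higher numbers for weaker inhibition), compound 1 gives "not determined" (no result reported)
- Compound 2 `COc1ccc(/C=C\C(=O)O)c(OCc2cn(-c3cccc([N+](=O)[O-])c3)nn2)c1CC=C(C)C`: in this assay compound 2 gives 43200 nM

For the measured compounds named here, compound 2 holds the only number in this assay; compound 1 carries no result, so nothing can be said about its standing. Going by the values given here, no pair of measured compounds differs in a single place, and so no measured step is available to set the size or direction of any change.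

Compound 3 `COc1ccc(/C=C\C(=O)O)c(OCc2cn(-c3ccccc3C#N)nn2)c1CC=C(C)C` is the next entry. Compared with compound 2 it carries 2-cyanophenyl in place of 3-nitrophenyl on an aromatic nitrogen. Among the compounds with values here, with no measured step to lean on, the expectation for the step from compound 2 to compound 3 is set at a 1.1-fold lower number from compound 2 to compound 3 (0.03 log units; within the scatter), that is, none beyond the scatter. Compound 3 is therefore estimated at 40000 nM in this assay, with a range from 15000 nM to 110000 nM.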

Compound 3, half-maximal inhibitory concentration: 14400 nM
Estimate against measurement, compound 3: 2.8-fold (0.44 log units) above; the measured number lies below the stated range.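

The aryl group on the ring nitrogen is now shown to matter: in this assay the swap to 2-cyanophenyl in place of 3-nitrophenyl gives a 3.0-fold lower number from compound 2 to compound 3 (0.48 log units; beyond the scatter) in a single measured step. This step changes the substituent and its place on the phenyl ring together, so it cannot assign the shift to either one alone. Nothing measured bears on why the number moves.

With one step, no trend across aryl groups can be drawn, and compound 1 adds nothing because it carries no result. Going by these compounds, how a plain phenyl group, or a phenyl ring carrying an amine or a carboxylic acid, would read on this ring nitrogen remains open, as does whether any such group would take the number lower than compound 3 does.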